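The compounds below may be only part of what the source reports. "The series", "measured", "known", "first", "only" and "open" are said of these compounds alone.

In a physicochemical assay for pharmacokinetics (a higher number here means that the compound lasts longer, a lower number that the compound disappears faster), compound 1 `O=C(NCc1ccccc1F)N1C(=O)c2ccccc2S1(=O)=O` gives 0.598 h and compound 2 `O=C(NCc1ccc(C(F)(F)F)cc1)N1C(=O)c2ccccc2S1(=O)=O` gives 0.212 h. Compound 2 therefore has the lower of the two numbers, and its gap to compound 1 lies beyond the scatter. Compound 3 `O=C(NCc1ccccc1)N1C(=O)c2ccccc2S1(=O)=O` differs from compound 2 by hydrogen in place of trifluoromethyl on an aromatic carbon. Going by the values given here, no measured pair shows this change alone. Among the compounds with values here, the only guide is compound 1, which carries no trifluoromethyl and gives 0.598 h, so a moderate rise is expected. The expected step is a 2.1-fold higher number from compound 2 to compound 3 (0.33 log units; beyond the scatter). For compound 3 the estimate is 0.45 h, within an expected range of 0.18 h to 1.1 h.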

Compound 3, half-life: 1.02 h
Beside the measured number, compound 3's estimate is 2.3-fold (0.36 log units) below it, within the range that was stated.
By their numbers in this assay, from the lowest: compound 2; then compounds 1 and 3 (each within the scatter of the next).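

In this assay, hydrogen in place of trifluoromethyl on this aromatic carbon gives a 4.8-fold higher number from compound 2 to compound 3 (0.68 log units; beyond the scatter) and so shows that this single change alone moves the half-life beyond the scatter. Hydrogen in place of fluoro gives a 1.7-fold higher number from compound 1 to compound 3 (0.23 log units; within the scatter) and stays within the scatter, so that change shows no clear difference. No supporting measurement bears on what lies behind the larger step.

Still open, going by these compounds, is how a methoxy group, an amine or a carboxylic acid on this aromatic carbon would compare with hydrogen and trifluoromethyl.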